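A Substituted Pyrrolidine Replaces the Cyclopentyl Amine

This account rests on a few compounds, and the source may have more. Where it says the series, first, only, none or still open, it means among the compounds named here.

Of the compounds shown here, three sharing one core have been tested in a functional assay on HEK293 cells for activation of melanin-concentrating hormone receptor 1 (Rattus norvegicus), read by inositol phosphate accumulation; a lower number here means that less compound is needed, a higher number that more compound is needed for the effect. Compound 1 `O=C(CCc1ccc(C(F)(F)F)cc1)Nc1ccc2nc(N3CCC3)ccc2c1` gives 56 nM. Compound 2 `CN(c1ccc2cc(NC(=O)CCc3ccc(C(F)(F)F)cc3)ccc2n1)C1CCCCC1` gives 1200 nM, and compound 3 `CN(c1ccc2cc(NC(=O)CCc3ccc(C(F)(F)F)cc3)ccc2n1)C1CCCC1` gives 350 nM. Compound 3 therefore stands second highest of the three numbers, with a 3.4-fold lower number from compound 2 to compound 3 (0.54 log units; beyond the scatter) separating it from compound 2 and a 6.3-fold higher number from compound 1 to compound 3 (0.80 log units; beyond the scatter) separating it from compound 1.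

Compound 4 `CC(C)C(=O)NC1CCN(c2ccc3cc(NC(=O)CCc4ccc(C(F)(F)F)cc4)ccc3n2)C1` differs from compound 3 in one place: 3-((isopropylcarbonyl)amino)pyrrolidin-1-yl in place of cyclopentyl(methyl)amino on an aromatic carbon. Among the compounds with values here, two measured steps bear on this. One is a 6.3-fold higher number from compound 1 to compound 3 (0.80 log units; beyond the scatter), where azetidin-1-yl gave way to cyclopentyl(methyl)amino. The other is a 3.4-fold lower number from compound 2 to compound 3 (0.54 log units; beyond the scatter), where cyclohexyl gave way to cyclopentyl. Together they show that compound 1, whose ring is attached directly to the nitrogen, has the lowest number of the three. Compound 4 again carries a ring attached directly to the nitrogen, now with an amide on it, so the number is expected to fall, by about a 2.3-fold lower number from compound 3 to compound 4 (0.37 log units; beyond the scatter). Compound 4 is thus estimated at 150 nM, within a range of 30 nM to 800 nM.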

Compound 4, half-maximal effective concentration: 90 nM
For compound 4 the middle estimate is 1.7-fold (0.22 log units) above the measured one; low and high end bracket the measured number.
By their numbers in this assay, from the lowest: compounds 1 and 4 (each within the scatter of the next); then compound 3; then compound 2.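

In this assay, the group on the aromatic carbon next to the ring nitrogen can gain heavy atoms without the number rising: 3-((isopropylcarbonyl)amino)pyrrolidin-1-yl brings a 3.9-fold lower number from compound 3 to compound 4 (0.59 log units; beyond the scatter) and a 13-fold lower number from compound 2 to compound 4 (1.12 log units; beyond the scatter). This larger amide-bearing group also cannot be told apart from the azetidin-1-yl ring, with a 1.6-fold higher number from compound 1 to compound 4 (0.21 log units; within the scatter), so a bigger substituent at this position need not mean that more compound is required. Nothing measured here accounts for these steps.

The compounds shown leave open whether the amide or the pyrrolidine ring matters more, a question that a bare pyrrolidin-1-yl or a free amine on that ring could help to separate. From the compounds shown here alone, how a longer chain on the carbonyl would behave also remains open.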